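Dropping the Ester Group: Little Change Expected

The compounds below may be only part of what the source reports. "The series", "measured", "known", "first", "only" and "open" are said of these compounds alone.

Of the compounds shown here, three sharing one core have been tested in a functional assay for inhibition of nuclear factor NF-kappa-B complex (Homo sapiens); a higher number here means a weaker inhibitor, a lower number a stronger inhibitor. Compound 1 `COc1ccc2c(c1)OC(c1cc(OC)c(OC)c(OC)c1)C(C(=O)OC(C)C)=C2` gives 11800 nM, compound 2 `COc1ccc2c(c1)OC(c1cc(OC)c(OC)c(OC)c1)C(C(=O)Nc1ccccc1)=C2` gives 17500 nM, and compound 3 `COC(=O)C1=Cc2ccc(OC)cc2OC1c1cc(OC)c(OC)c(OC)c1` gives 13800 nM. Compound 3 sits among the others: the step of a 1.2-fold higher number from compound 1 to compound 3 (0.07 log units; within the scatter) and the step of a 1.3-fold lower number from compound 2 to compound 3 (0.10 log units; within the scatter) are both small, as is the step of a 1.5-fold higher number from compound 1 to compound 2 (0.17 log units; within the scatter). All three changes swap one group for another on the carbonyl carbon. Compound 4 `COc1ccc2c(c1)OC(c1cc(OC)c(OC)c(OC)c1)C=C2` goes further: hydrogen in place of methoxycarbonyl on a double-bonded ring carbon. Among the compounds with values here, no measured step removes this group outright, so the three small steps only suggest that changes at this position have mattered little. A step of a 1.4-fold higher number from compound 3 to compound 4 (0.16 log units; within the scatter) is therefore expected, leaning slightly toward a weaker inhibitor. Compound 4 is estimated at 20000 nM, with a range from 7000 nM to 60000 nM.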

Compound 4, half-maximal inhibitory concentration: 17700 nM
Beside the measured number, compound 4's estimate is 1.1-fold (0.05 log units) above it; low and high end bracket the measured number.
By their numbers in this assay, from the lowest: compounds 1, 3, 2 and 4 (each within the scatter of the next).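

Taking the group off entirely, rather than swapping it, can now be read directly in this assay: hydrogen in place of methoxycarbonyl gives a 1.3-fold higher number from compound 3 to compound 4 (0.11 log units; within the scatter) while hydrogen in place of phenylcarbamoyl gives a 1.0-fold higher number from compound 2 to compound 4 (0.00 log units; within the scatter) and hydrogen in place of isopropoxycarbonyl gives a 1.5-fold higher number from compound 1 to compound 4 (0.18 log units; within the scatter) on this double-bonded ring carbon. In this assay, these three carbonyl-bearing groups and plain hydrogen cannot be told apart at this position. Nothing available explains this result. Still open, on these data alone, is whether a carboxylic acid or an amine on a longer chain at this position would give a different number.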